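Series notes: chloro replaces hydrogen on the benzamido ring

A few compounds are considered here, and "the series" means these few. Any claim that something is new, unique, unknown or untested is made for them only; others in the source may bear on it.

Compound 3 `O=C(CSc1nc2ccc(NC(=O)c3ccccc3)cc2s1)NCc1ccccc1` gives 34200 nM in a functional assay on HepG2 cells (Homo sapiens) for cytotoxicity, read by MTT assay, with a stated time of 48 h (on this read-out lower numbers stand for stronger inhibition and higher numbers for weaker inhibition), the highest of the two numbers shown. Compound 2 `CC(=O)Nc1ccc2nc(SCC(=O)NCc3ccccc3)sc2c1` gives 9200 nM, and a 3.7-fold higher number from compound 2 to compound 3 (0.57 log units; beyond the scatter) when the carbonyl carries phenyl in place of methyl. Compound 1 `O=C(CSc1nc2ccc(NC(=O)c3ccc([N+](=O)[O-])cc3)cc2s1)NCc1ccccc1` gives > 100000 nM, which is a limit of the assay rather than a number (the limit of > 100000 nM in this assay, at which 1 of the 3 values shown sits). Removing nitro gives an at least 2.9-fold lower number from compound 1 to compound 3 (0.46 log units; beyond the scatter), and putting methyl on the carbonyl gives an at least 10-fold lower number from compound 1 to compound 2 (1.03 log units; beyond the scatter).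

Compound 4 `O=C(CSc1nc2ccc(NC(=O)c3ccc(Cl)cc3)cc2s1)NCc1ccccc1` differs from compound 3 by chloro in place of hydrogen on an aromatic carbon. For the measured compounds named here, the one measured step that touches the same place is the loss of nitro, an at least 2.9-fold lower number from compound 1 to compound 3 (0.46 log units; beyond the scatter): a group on that aromatic carbon, para to a large group, went with a higher number on the single occasion it was tried. Chloro is not nitro, and no other step bears on it, so the expectation is a step in the same direction as nitro gave, but smaller, or possibly none beyond the scatter. Compound 4 is estimated at 50000 nM, within 18000 nM to 110000 nM, an expected 1.5-fold higher number from compound 3 to compound 4 (0.16 log units; within the scatter).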

Compound 4, half-maximal inhibitory concentration: 25400 nM
The estimate for compound 4 lay 2.0-fold (0.29 log units) above the measured number, within the range that was stated.
By their numbers in this assay, from the lowest: compound 2; then compounds 4 and 3 (each within the scatter of the next). At a limit, above all of these: compound 1.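

In this assay, chloro at this aromatic carbon, para to a large group, gives a 1.3-fold lower number from compound 3 to compound 4 (0.13 log units; within the scatter), so a substituent there does not in itself go with a higher number, which the loss of nitro alone could not show. Chloro and nitro are also not interchangeable at this carbon, with an at least 3.9-fold lower number from compound 1 to compound 4 (0.59 log units; beyond the scatter), although that size is only a bound, as compound 1 stands at a limit: the limit of > 100000 nM in this assay, at which 1 of the 4 values shown sits.

Against methyl on the carbonyl, 4-chlorophenyl gives a 2.8-fold higher number from compound 2 to compound 4 (0.44 log units; beyond the scatter), so in both cases shown, compound 3 and compound 4, an aromatic ring on that carbonyl goes with a higher number than the methyl of compound 2, whether the ring carries hydrogen or chloro.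

Whether a methoxy group, an amine or a carboxylic acid on the same carbon would stay with chloro or move towards nitro remains open, since only these two substituents are shown there. Also open, from the compounds shown here alone, is where a longer chain, such as propyl or butyl, would fall on the carbonyl relative to methyl and the aromatic rings.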